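From bromo to chloro in a small antiproliferative series

The compounds below may be only part of what the source reports. "The series", "measured", "known", "first", "only" and "open" are said of these compounds alone.

Measured in a functional assay on MCF7 cells (Homo sapiens) for antiproliferative activity, read by MTT assay, with a stated time of 48 h; a lower number here means a stronger inhibitor, a higher number a weaker inhibitor:
- compound 1 `COc1ccc(C(=O)/C=C/c2cccc(Cl)c2Oc2c([N+](=O)[O-])cc(C(F)(F)F)cc2[N+](=O)[O-])cc1` gives 1.83 ug/mL
- compound 2 `O=C(/C=C/c1cc(Cl)cc(Cl)c1Oc1c([N+](=O)[O-])cc(C(F)(F)F)cc1[N+](=O)[O-])c1ccc(F)cc1` gives 5.02 ug/mL
- compound 3 `O=C(/C=C/c1cccc(Br)c1Oc1c([N+](=O)[O-])cc(C(F)(F)F)cc1[N+](=O)[O-])c1ccc(F)cc1` gives 6.01 ug/mL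

Compound 3 at 6.01 ug/mL and compound 2 at 5.02 ug/mL lie within the usual scatter of each other. Compound 1 has a lower number than compound 3 by more than the scatter, so it is the stronger inhibitor of that pair.

Compound 4 `O=C(/C=C/c1cccc(Cl)c1Oc1c([N+](=O)[O-])cc(C(F)(F)F)cc1[N+](=O)[O-])c1ccc(F)cc1` differs from compound 3 in one place (chloro in place of bromo on an aromatic carbon) with chloro in place of bromo on an aromatic carbon. Among the measured compounds shown here, no measured pair shows this swap alone. Compound 2 at 5.02 ug/mL carries chloro in that place plus a further chloro, and it sits within the scatter of compound 3. Compound 1 at 1.83 ug/mL also carries chloro there but differs elsewhere, so its lower number cannot be credited to the chloro alone. The expected 1.3-fold lower number from compound 3 to compound 4 (0.13 log units; within the scatter) stays within the scatter in this assay and is no more than a small shift. Compound 4 is estimated at 4.5 ug/mL with an expected range from 2 ug/mL to 10 ug/mL in this measurement.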

Compound 4, half-maximal inhibitory concentration: 5.17 ug/mL
Compound 4: middle estimate off by 1.1-fold (0.06 log units), on the low side; measured number inside the range.
By their numbers in this assay, from the lowest: compound 1; then compounds 2, 4 and 3 (each within the scatter of the next).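

Chloro in place of bromo, read alone for the first time, gives a 1.2-fold lower number from compound 3 to compound 4 (0.07 log units; within the scatter) in this assay, so at this place, ortho to a large group, the two halogens cannot be told apart in this assay. Hydrogen in place of the further chloro gives a 1.0-fold higher number from compound 2 to compound 4 (0.01 log units; within the scatter), so that extra chloro shows no measurable effect either. Fluoro in place of methoxy gives a 2.8-fold higher number from compound 1 to compound 4 (0.45 log units; beyond the scatter), which places the gap between compound 1 and compound 4 at that other aromatic carbon, where the chloro is shared and plays no part.

Nothing measured here explains the size of any of these steps. As far as these compounds go, it also remains open whether an amine or a nitrile at the halogen's place would shift the number more than the swap of one halogen for another does.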